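Methyl in Place of Ethynyl on the Shared Core

The source may hold more compounds than are shown below. What is called first, only, known or untested is meant among the compounds shown, and "the series" means these compounds.

Measured compounds:
Compound 1 `CCCCNc1nc(N)nc(C)c1CC` gives 1660 nM in an assay on HEK293 cells for agonist activity at Toll-like receptor 8 (Homo sapiens), read by spectrophotometry; on this read-out higher numbers stand for an effect only at larger amounts of compound and lower numbers for an effect already at smaller amounts.
Compound 2 `CCCCCc1c(C)nc(N)nc1NCCCC` gives 1220 nM in this assay.
Compound 3 `C#Cc1c(C)nc(N)nc1NCCCC` gives 4900 nM in this assay.

Compound 3 stands highest of the three numbers in this assay: the step of a 3.0-fold higher number from compound 1 to compound 3 (0.47 log units; beyond the scatter) and the step of a 4.0-fold higher number from compound 2 to compound 3 (0.60 log units; beyond the scatter) both lie beyond the scatter, while the step of a 1.4-fold lower number from compound 1 to compound 2 (0.13 log units; within the scatter) lies within it. Compound 4 `CCCCNc1nc(N)nc(C)c1C` differs from compound 3 by methyl in place of ethynyl on an aromatic carbon. The two steps that bear on this change, from compound 1 to compound 3 and from compound 2 to compound 3, each put ethynyl in place of a saturated chain and each raised the number in this assay by a modest amount. Compound 4 reverses that kind of exchange, though with a chain shorter than either ethyl or pentyl, so a modest drop in the number is expected, with the estimated step of a 2.0-fold lower number from compound 3 to compound 4 (0.31 log units; beyond the scatter). Compound 4 is therefore expected to give about 2400 nM in this assay, within a range of 1000 nM to 6000 nM.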

Compound 4, half-maximal effective concentration: 3280 nM
Compound 4: the middle estimate sits 1.4-fold (0.14 log units) below what was measured; the range from low to high includes it.
By their numbers in this assay, from the lowest: compounds 2, 1, 4 and 3 (each within the scatter of the next, the first and the last beyond it).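

In this assay the step of a 1.5-fold lower number from compound 3 to compound 4 (0.17 log units; within the scatter) shows that on this aromatic carbon, ortho to a butylamino group, methyl and ethynyl cannot be told apart. The earlier steps shown here had set ethynyl off from ethyl and pentyl, yet methyl, also a saturated group, does not share that separation from ethynyl. Among the saturated groups, a 2.0-fold higher number from compound 1 to compound 4 (0.30 log units; within the scatter) leaves methyl and ethyl unresolved, while a 2.7-fold higher number from compound 2 to compound 4 (0.43 log units; beyond the scatter) marks a modest gap between methyl and pentyl at this carbon.

As far as these compounds go, whether an amine, a carboxylic acid or a chain longer than pentyl on this carbon would move the number further in either direction stays open. The data shown offer no measurement that accounts for any of these steps.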